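A few compounds are considered here, and "the series" means these few. Any claim that something is new, unique, unknown or untested is made for them only; others in the source may bear on it.

Three esters of a crown-ether alcohol have been measured in a functional assay on WiDr cells (Homo sapiens) for inhibition, read by sulforhodamine B assay, with a stated time of 48 h; a higher number here means a weaker inhibitor of growth, a lower number a stronger inhibitor of growth. Compound 1, `O=C(CCCCC1CCCCC1)OCC1COCCOCCOCCOCCO1`, with the smaller crown, gives only a limit, > 100000 nM, which marks (the limit of > 100000 nM in this assay, at which 1 of the 3 values shown sits). Compound 2, `O=C(CCCCC1CCCCC1)OCC1COCCOCCOCCOCCOCCO1`, gives 33000 nM. Compound 3, `CC(C)=CC1C(C(=O)OCC2COCCOCCOCCOCCOCCO2)C1(C)C`, gives 56000 nM, the higher of the two numbers, yet the step of a 1.7-fold higher number from compound 2 to compound 3 (0.23 log units; within the scatter) is within the scatter, so the two cannot be ranked. Compound 4 is `O=C(CCCCOc1ccccc1)OCC1COCCOCCOCCOCCOCCO1`. It differs from compound 3 by 4-phenoxybutyl in place of 2,2-dimethyl-3-(2-methylprop-1-en-1-yl)cyclopropyl on a carbonyl carbon. Going by the values given here, the only measured step that bears on this kind of exchange of the acyl group, a 1.7-fold higher number from compound 2 to compound 3 (0.23 log units; within the scatter), was small, so the expected step of a 1.2-fold lower number from compound 3 to compound 4 (0.09 log units; within the scatter) in this assay is also expected to stay within the scatter, with no direction claimed. On that basis compound 4 is estimated at 45000 nM, with a likely range from 15000 nM to 150000 nM.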

Compound 4, concentration for 50% growth inhibition: > 100000 nM
Compound 4 was reported as a limit; the forecaster's own chance of this, stated with the estimate: 25%; middle value at least 2.2-fold (0.34 log units) away from the limit.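

In this assay the acyl group no longer looks indifferent: phenoxy in place of cyclohexyl on a saturated chain carbon, four bonds along the chain from a carbonyl carbon, gives an at least 3.0-fold higher number from compound 2 to compound 4 (0.48 log units; beyond the scatter), whereas the earlier acyl exchange stayed within the scatter. The comparison with the cyclopropyl ester is less telling, with an at least 1.7-fold higher number from compound 3 to compound 4 (0.25 log units; that floor lies within the scatter), so that pair is not firmly separated. Compound 4 is reported only as a limit, so the true size of both steps stays unknown, and limits now make up a larger share of the series: the limit of > 100000 nM in this assay, at which 2 of the 4 values shown sit.

Phenoxy differs from cyclohexyl in both its aromatic ring and its oxygen, and the step does not tell which of the two matters. On these data alone, a phenyl or cyclohexyloxy group on that chain would separate them, and the effect of an amine there also remains open.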